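Shortening the ester chain on a PAK 4 inhibitor scaffold

The compounds below may be only part of what the source reports. "The series", "measured", "known", "first", "only" and "open" are said of these compounds alone.

Measured compounds:
compound 1 `CC(C)COC(=O)N1CCN(C(=O)c2nc(Nc3cc(C4CC4)[nH]n3)c3cc(Cl)ccc3n2)C[C@H]1C` with 46.9%
compound 2 `CC(OC(=O)C(C)C)OC(=O)N1CCN(C(=O)c2nc(Nc3cc(C4CC4)[nH]n3)c3cc(Cl)ccc3n2)C[C@H]1C` with 71.7%
compound 3 `C[C@@H]1CN(C(=O)c2nc(Nc3cc(C4CC4)[nH]n3)c3cc(Cl)ccc3n2)CCN1C(=O)OCOC(=O)C(C)(C)C` with 60.5%

In an assay for inhibition of serine/threonine-protein kinase PAK 4 (Homo sapiens), read by FRET and Z'-LYTE, with a stated time of 60 min, tested at 50 uM, in the presence of a further agent that is not named here (a higher number here means a stronger effect of the compound at the concentration tested, a lower number a weaker effect), compound 1 gives 46.9%, the lowest of the three numbers. Compound 3 stands nearest, with a number 13.6 percentage points higher from compound 1 to compound 3 (beyond the scatter), and compound 2 furthest, with a number 24.8 percentage points higher from compound 1 to compound 2 (beyond the scatter); between those two the difference is a number 11.2 percentage points lower from compound 2 to compound 3 (beyond the scatter). Compound 4 `CCOC(=O)N1CCN(C(=O)c2nc(Nc3cc(C4CC4)[nH]n3)c3cc(Cl)ccc3n2)C[C@H]1C` is not yet measured. It differs from compound 1 as follows: methyl in place of isopropyl on a saturated chain carbon bound to an oxygen next to a carbonyl group. Both measured steps from compound 1 replace or extend the group on that oxygen with a larger one and move the number upward by a modest amount. Among the compounds with values here, compound 4 instead carries a smaller group, ethyl in place of isobutyl, for which no measured step exists. Within the data shown here, no step from the three compounds points to a gain for this change, so the expectation is a number near that of compound 1, with a small downward lean that stays within the scatter. Compound 4 is therefore expected at 42%, between 25% and 60%, which means an estimated step of a number 4.9 percentage points lower from compound 1 to compound 4 (within the scatter).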

Compound 4, a percentage reported as inhibition, at one concentration (the size of the read-out at that concentration, not a potency): 93.4%
The estimate for compound 4 lay 51.4 percentage points below the measured number, outside the stated range (above it).
By their numbers in this assay, from the lowest: compound 1; then compound 3; then compound 2; then compound 4.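

In this assay, replacing isobutyl with ethyl gives a number 46.5 percentage points higher from compound 1 to compound 4 (beyond the scatter), a larger move at this place than either earlier step, and it comes from a smaller group rather than a larger one. The ethyl group also surpasses both ester-bearing groups, with a number 32.9 percentage points higher from compound 3 to compound 4 (beyond the scatter) and a number 21.7 percentage points higher from compound 2 to compound 4 (beyond the scatter), which leaves compound 4 highest of the four. The number therefore does not follow group size at this place: compound 1, with isobutyl, stands lowest, below the larger groups of compound 2 and compound 3, yet above it stands the smaller ethyl of compound 4.

Nothing available accounts for the height of the ethyl result. As far as these compounds go, whether a methyl group or an unbranched propyl chain on that oxygen would hold this number remains open.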